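This account rests on a few compounds, and the source may have more. Where it says the series, first, only, none or still open, it means among the compounds named here.

Measured compounds:
- compound 1, `O=C(NS(=O)(=O)c1ccccc1)c1ccc(Nc2nc(NC3(c4ccc(Cl)cc4)CC3)nc(OCC(F)(F)F)n2)cc1`: 100%
- compound 2, `CC(C)(C)NC(=O)NCCS(=O)(=O)NC(=O)c1ccc(Nc2nc(NC3(c4ccc(Cl)cc4)CC3)nc(OCC(F)(F)F)n2)cc1`: 96%
- compound 3, `CC(C)(C)CNCCS(=O)(=O)NC(=O)c1ccc(Nc2nc(NC3(c4ccc(Cl)cc4)CC3)nc(OCC(F)(F)F)n2)cc1`: 89%

All three share one core and differ only in the group on the sulfonyl sulfur. In an ADME assay on microsomes from liver (Homo sapiens) for metabolic stability, with a stated time of 10 min (on this read-out higher numbers stand for a more stable compound and lower numbers for a less stable compound), compound 2 lies between compound 1 and compound 3, and both gaps, a number 4 percentage points lower from compound 1 to compound 2 (within the scatter) and a number 7 percentage points lower from compound 2 to compound 3 (within the scatter), stay within the scatter; only compound 3 stands apart from compound 1, by a number 11 percentage points lower from compound 1 to compound 3 (beyond the scatter).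

Compound 4, `O=C(NS(=O)(=O)C1CC1)c1ccc(Nc2nc(NC3(c4ccc(Cl)cc4)CC3)nc(OCC(F)(F)F)n2)cc1`, is not yet measured. Its change from compound 2 is cyclopropyl in place of 2-(((tert-butyl)carbamoyl)amino)ethyl on a sulfonyl sulfur. The two steps that alter the same position, a number 4 percentage points lower from compound 1 to compound 2 (within the scatter) and a number 11 percentage points lower from compound 1 to compound 3 (beyond the scatter), leave the read-out of this assay nearly unchanged or only modestly lower. Within the data shown here, no measured step introduces a cyclopropyl at this position, so the expectation rests on how little the position has mattered so far. For compound 4 no step beyond the scatter is expected from compound 2, a number 1 percentage points lower from compound 2 to compound 4 (within the scatter), in this assay. Compound 4 is therefore estimated at 95%, within 85% to 100%.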

Compound 4, percent of the compound remaining: 100%
Compound 4: the middle estimate sits 5 percentage points below what was measured; the measured number falls inside the stated range.
By their numbers in this assay, from the lowest: compounds 3, 2, 1 and 4 (each within the scatter of the next, the first and the last beyond it).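

In this assay, replacing the phenyl or the 2-(((tert-butyl)carbamoyl)amino)ethyl group with cyclopropyl on the sulfonyl sulfur gives no step beyond the scatter: no change at the digits printed from compound 1 to compound 4 (within the scatter), and a number 4 percentage points higher from compound 2 to compound 4 (within the scatter). Among these compounds, the only step beyond the scatter that involves compound 4 is a number 11 percentage points higher from compound 3 to compound 4 (beyond the scatter), so compound 3 now stands apart from two small groups on the sulfur, phenyl and cyclopropyl, while compound 2 stands apart from neither. No measurement offers a reason for these numbers.

Compound 1 and compound 4 both sit at the top of the scale, so any difference between them cannot be seen at this single stated time. As far as these compounds go, how a primary amine, a carboxylic acid or a longer alkyl chain on the sulfur would behave remains open.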